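Changing the Side Chain of Compound 2

This account rests on a few compounds, and the source may have more. Where it says the series, first, only, none or still open, it means among the compounds named here.

Compound 1 `CCCCC/C=C\C/C=C\CCCCCCCC1(O)CC(=O)c2c(O)cc(OCOC)cc2O1`: > 84100 nM (a limit)
Compound 2 `CCCCCCCCCCCC1(O)CC(=O)c2c(O)cc(O)cc2O1`: 43200 nM

Going by the values given here, in a functional assay on MCF7 cells (Homo sapiens) for antiproliferative activity, read by MTT assay (on this read-out lower numbers stand for stronger inhibition and higher numbers for weaker inhibition), compound 2 gives 43200 nM, the only true number so far. Compound 1 reads > 84100 nM, which is a limit of the assay and not a number.

Compound 3 `CCCCC/C=C\C/C=C\CCCCCCCC1(O)CC(=O)c2c(O)cc(O)cc2O1` has not yet been measured. It keeps the shared core of compound 2 and differs only in the side chain: deca-1,4-dien-1-yl in place of butyl on a saturated chain carbon, seven bonds along the chain from a saturated ring carbon. The new chain is therefore longer and carries double bonds that the old one lacks.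

Among the compounds with values here, no two measured compounds differ in just one place, so the data offer no measured step to use as a guide for this change. Without such a guide there is no basis for choosing a direction, and the expectation in this assay is no change beyond the usual scatter of repeated measurements. The expected shift is a 1.1-fold lower number from compound 2 to compound 3 (0.03 log units; within the scatter). The estimate stays close to compound 2 at 43200 nM, the only numerical anchor available. For compound 3 the estimated value is 40000 nM, with an expected range of 15000 nM to 84000 nM.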

Compound 3, half-maximal inhibitory concentration: 17500 nM
Beside the measured number, compound 3's estimate is 2.3-fold (0.36 log units) above it; the measured number falls inside the stated range.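

In this assay, going by these compounds alone, the first measured step in the side chain shows that this position affects activity: deca-1,4-dien-1-yl in place of butyl on a saturated chain carbon, seven bonds along the chain from a saturated ring carbon, gives a 2.5-fold lower number from compound 2 to compound 3 (0.39 log units; beyond the scatter). A second place on the molecule now has a measured step too, as hydrogen in place of methoxymethyl on an oxygen on an aromatic ring gives an at least 4.8-fold lower number from compound 1 to compound 3 (0.68 log units; beyond the scatter). That size is only a minimum, and the reading for compound 1 is a limit and not a number: the limit of > 84100 nM in this assay, at which 1 of the 3 values shown sits.

The side-chain step changes length and adds double bonds at the same time, so the compounds shown cannot tell which of the two changes goes with the lower number. A saturated decyl chain at this position would separate the two, and a longer chain or a chain ending in an amine would show whether the trend continues or how far this position tolerates a different group.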